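This account rests on a few compounds, and the source may have more. Where it says the series, first, only, none or still open, it means among the compounds named here.

Measured compounds:
- compound 1, `CCCCCCCCCCOP(=O)(O)OCCSC(=S)N1CCCC1`: 67000 nM
- compound 2, `CCCCCCCCCCOP(=O)(O)OCCSC(=S)N1CCCCC1`: 24600 nM
- compound 3, `CCCCCCCCCCCCCCCCOP(=O)(O)OCCSC(=S)N1CCCCC1`: 100000 nM

In a functional assay on MDA-MB-231 cells (Homo sapiens) for inhibition, read by MTT assay, with stated times of 18 h and 4 h (a lower number here means a stronger inhibitor, a higher number a weaker inhibitor), compound 2 gives the lowest number of the three. The change pyrrolidin-1-yl in place of piperidin-1-yl on a thiocarbonyl carbon gives a 2.7-fold higher number from compound 2 to compound 1 (0.44 log units; beyond the scatter). The cores of compound 2 and compound 3 differ by hexyl in place of hydrogen on a saturated chain carbon, ten or more bonds along the chain from an oxygen on an unsaturated carbon, which gives a 4.1-fold higher number from compound 2 to compound 3 (0.61 log units; beyond the scatter). Compound 4, `CCCCCCCCCCCCCCCCOP(=O)(O)OCCSC(=S)N1CCCC1`, has not yet been measured; it differs from compound 3 by pyrrolidin-1-yl in place of piperidin-1-yl on a thiocarbonyl carbon, the same change made from compound 2 to compound 1, at the same place. Among the compounds with values here, the step from compound 3 to compound 4 is expected to be a 2.2-fold higher number from compound 3 to compound 4 (0.34 log units; beyond the scatter), about as large as the one from compound 2 to compound 1, since the change is the same, though it rests on only one measured pair. Compound 4 is therefore expected to give 220000 nM, likely between 90000 nM and 500000 nM.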

Compound 4, half-maximal inhibitory concentration: 69000 nM
Beside the measured number, compound 4's estimate is 3.2-fold (0.50 log units) above it, and the stated range ends above it.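

In this assay, pyrrolidin-1-yl in place of piperidin-1-yl on a thiocarbonyl carbon gives a 1.4-fold lower number from compound 3 to compound 4 (0.16 log units; within the scatter), so the step seen on the core of compound 2 did not carry over to the core of compound 3: the same change on two cores in this assay, a 2.7-fold higher number (0.44 log units; beyond the scatter) from compound 2 to compound 1 and a 1.4-fold lower number (0.16 log units; within the scatter) from compound 3 to compound 4, 3.9-fold (0.60 log units) apart, beyond the scatter of two such steps The longer-chain change, hexyl in place of hydrogen on a saturated chain carbon, gives a 1.0-fold higher number from compound 1 to compound 4 (0.01 log units; within the scatter), so it too depends on the core that carries it: the same change on two cores in this assay, a 4.1-fold higher number (0.61 log units; beyond the scatter) from compound 2 to compound 3 and a 1.0-fold higher number (0.01 log units; within the scatter) from compound 1 to compound 4, 3.9-fold (0.60 log units) apart, beyond the scatter of two such steps The two changes therefore do not add up across these four compounds, but two pairs per change cannot show how either would behave on any other core, nor why the steps differ.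

The compounds shown leave open how a morpholin-4-yl group on the thiocarbonyl carbon would behave. They also leave open how a dodecyl chain would fit these steps.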